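Swapping the ring group on a shared core

This account rests on a few compounds, and the source may have more. Where it says the series, first, only, none or still open, it means among the compounds named here.

In an ADME assay on microsomes from liver (Mus musculus) for metabolic stability, read by LC-MS, with a stated time of 10 min (a higher number here means that more of the compound is left, a lower number that less of the compound is left), compound 3 (`CN(C[C@H]1Cc2c(cccc2N2CCN3CCC[C@@H]3C2)CN1)[C@H]1CCCc2cccnc21`) gives 36.7%. That is within the scatter of compound 1 (`CN(C[C@H]1Cc2c(cccc2N2CCNC(C)(C)C2)CN1)[C@H]1CCCc2cccnc21`) at 44% and well apart from compound 2 (`CC(C)N1CCN(c2cccc3c2C[C@H](CN(C)[C@H]2CCCc4cccnc42)NC3)CC1`) at 15.1%. These three compounds share one core and differ only in the group on an aromatic carbon.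

Compound 4 (`CN(C[C@H]1Cc2c(cccc2N2C[C@@H]3C[C@H]2CN3)CN1)[C@H]1CCCc2cccnc21`) keeps that core and changes the same group again: a group of 7 heavy atoms (5 carbon, 2 nitrogen; 2 five-membered non-aromatic rings with 1 hetero atom each) in place of a group of 9 heavy atoms (7 carbon, 2 nitrogen; one five-membered non-aromatic ring with 1 hetero atom, one six-membered non-aromatic ring with 2 hetero atoms), on an aromatic carbon. The group stands on an aromatic carbon of a six-membered aromatic ring of carbon only, so the three measured compounds offer the closest comparison.

Those compounds show how far a change at this place has moved the number. The measured steps are a number 7.3 percentage points lower from compound 1 to compound 3 (within the scatter), a number 21.6 percentage points higher from compound 2 to compound 3 (beyond the scatter) and a number 28.9 percentage points lower from compound 1 to compound 2 (beyond the scatter). Two of the three go beyond the scatter, so a swap here can matter, but both involve the 4-isopropylpiperazin-1-yl group of compound 2. Within the data shown here, no measured compound carries the entering group, and the data give no firm direction for it. The expectation is therefore no change beyond the scatter, and the estimated step is a number 1.7 percentage points lower from compound 3 to compound 4 (within the scatter).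

In this assay, the estimated value for compound 4 is 35%, with an expected range from 17% to 54%.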

Compound 4, percent of the compound remaining: 36.3%
For compound 4 the middle estimate is 1.3 percentage points below the measured one, within the range that was stated.
By their numbers in this assay, from the lowest: compound 2; then compounds 4, 3 and 1 (each within the scatter of the next).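

Swapping the group for one with two five-membered non-aromatic rings and a hydrogen-bond donor gives a number 0.4 percentage points lower from compound 3 to compound 4 (within the scatter) in this assay and a number 7.7 percentage points lower from compound 1 to compound 4 (within the scatter) on the same read-out, so a third ring group on this aromatic carbon joins the cluster formed by compound 1 and compound 3. The comparison with the outlier, a number 21.2 percentage points higher from compound 2 to compound 4 (beyond the scatter) in this same measure, shows that compound 2 with its 4-isopropylpiperazin-1-yl group is the only one of the four set apart, and the earlier large steps therefore reflect that one group rather than any swap at this place. Nothing measured here explains why the four numbers fall as they do.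

As far as these compounds go, whether a 4-methylpiperazin-1-yl group, with a shorter chain on the ring nitrogen, would read like compound 2 or like the other three stays open. Also open, from the compounds shown here alone, is how a morpholin-4-yl group, with an oxygen in the ring in place of one nitrogen, or the mirror-image form of the group in compound 4 would compare on this shared core.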